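The compounds below may be only part of what the source reports. "The series", "measured", "known", "first", "only" and "open" are said of these compounds alone.

Compound 1 `CC(C)(C)Cc1ccc2nc(N)sc2c1` and compound 2 `N=c1sc2cc(OC(F)(F)F)ccc2n1CC(=O)O` share a core and were both tested in a functional assay on the whole organism with Rattus norvegicus as the target; a higher number here means that more compound is needed for the effect, a lower number that less compound is needed. Compound 1 reaches only the assay limit of > 10 mg/kg. Compound 2 likewise reaches only the assay limit of > 10 mg/kg. Compound 2 therefore stands at the limit of > 10 mg/kg in this assay, at which 2 of the 2 values shown sit, with no number of its own. Compound 3 `N=c1sc2cc(OC(F)(F)F)ccc2n1CCS` is the next member, not yet measured in this assay. It differs from compound 2 by sulfanylmethyl in place of carboxy on a saturated chain carbon bound to an aromatic nitrogen. Going by the values given here, with no measured step to lean on, the step from compound 2 to compound 3 is expected to be small, a step that the limit leaves unreadable from compound 2 to compound 3, within scatter. Compound 3 is expected to give about 15 mg/kg in this assay, between 5 mg/kg and 50 mg/kg.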

Compound 3, dose for half-maximal effect: 2 mg/kg
Beside the measured number, compound 3's estimate is 7.5-fold (0.88 log units) above it; the whole stated range lies above it.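

In this assay, the saturated chain carbon bound to an aromatic nitrogen proves sensitive to change: sulfanylmethyl in place of carboxy gives an at least 5.0-fold lower number from compound 2 to compound 3 (0.69 log units; beyond the scatter). Of the compounds shown, only compound 3 yields a number rather than a limit. The step is a bound and not a full size, because compound 2 carries only a limit: the limit of > 10 mg/kg in this assay, at which 2 of the 3 values shown sit.

As far as these compounds go, whether the sulfur itself counts, or merely the loss of carboxy, stays open. A hydroxymethyl or aminomethyl group at this place, or a longer chain ending in sulfanyl, would separate the two.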